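The source may report more compounds than this note shows. Statements on the series, on what has been measured and on what is new or still open speak of the compounds shown alone.

Values in a functional assay (microsomes, liver) with Rattus norvegicus as the target; on this read-out lower numbers stand for stronger inhibition and higher numbers for weaker inhibition:
- compound 1 `Cc1c(C)c2c(c(N(C)C)c1N)CC(C)(C)O2`: 550 nM
- compound 2 `Cc1c(C)c2c(c(C)c1N)CC(C)(CSc1ccccc1)O2`: 270 nM
- compound 3 `Cc1c(C)c2c(c(C)c1N)CC(C)(CSc1nc3ccccc3s1)O2`: 70 nM

Compound 2, at 270 nM, stands in the middle of the three. Compound 1 gives a higher number and compound 3 a lower one, and both gaps lie beyond the scatter.

The next compound to be measured is compound 4 `CCCSCC1(C)Cc2c(C)c(N)c(C)c(C)c2O1`, which has propyl in place of phenyl on a sulfur. The rest of the structure matches compound 2. For the measured compounds named here, no measured pair isolates a change of this kind, and no measured compound carries a chain on that sulfur, so the data give no direct guide to its direction. The working expectation in this assay is therefore no step beyond the scatter, with a slight lean toward a higher number. The expected change is a 1.2-fold higher number from compound 2 to compound 4 (0.07 log units; within the scatter). For compound 4 the estimated value is 320 nM, with an expected range of 120 nM to 850 nM.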

Compound 4, half-maximal inhibitory concentration: 280 nM
Compound 4: the middle estimate sits 1.1-fold (0.06 log units) above what was measured; measured number inside the range.
By their numbers in this assay, from the lowest: compound 3; then compounds 2, 4 and 1 (each within the scatter of the next, the first and the last beyond it).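

In this assay, propyl on the sulfur in place of phenyl gives a 1.0-fold higher number from compound 2 to compound 4 (0.02 log units; within the scatter), a step within the scatter. At this position, then, a group with no ring and 3 heavy atoms reads alike with the six-membered aromatic ring of 6 heavy atoms, so an aromatic ring on this sulfur is not needed to reach the level of compound 2. Nothing available bears on why the two groups read alike.

Open, from the compounds shown here alone, is whether a longer chain on the sulfur, or a chain ending in an amine or a carboxylic acid, would stay at this level. Also open, going by these compounds, is which part of the sulfur substituent of compound 3 goes with its lower number of 70 nM.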